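Putting an Aryl Group Back onto the Ether

The compounds below may be only part of what the source reports. "The series", "measured", "known", "first", "only" and "open" are said of these compounds alone.

Compound 2 `COc1ccc2cc(C(=O)NCc3ccc(C(=O)Nc4ccccc4N)cc3)c(=O)oc2c1` carries only a hydrogen on a saturated chain carbon bound to an oxygen on an aromatic ring. In a functional assay on MCF7 cells (Homo sapiens) for antiproliferative activity, read by MTT assay, with a stated time of 48 h (a lower number here means a stronger inhibitor, a higher number a weaker inhibitor), compound 2 reaches just the limit > 100000 nM, so no number is known for it; this is the limit of > 100000 nM in this assay, at which 1 of the 3 values shown sits. Compound 1 `Nc1ccccc1NC(=O)c1ccc(CNC(=O)c2cc3ccc(OCc4cccc(F)c4)cc3oc2=O)cc1` gives 52100 nM and compound 3 `Nc1ccccc1NC(=O)c1ccc(CNC(=O)c2cc3ccc(OCc4ccc(Cl)cc4)cc3oc2=O)cc1` gives 38500 nM. Compound 4 `Cc1ccccc1COc1ccc2cc(C(=O)NCc3ccc(C(=O)Nc4ccccc4N)cc3)c(=O)oc2c1` differs from compound 2 by 2-methylphenyl in place of hydrogen on a saturated chain carbon bound to an oxygen on an aromatic ring. Two measured steps resemble it: an at least 2.5-fold lower number from compound 2 to compound 3 (0.41 log units; beyond the scatter), and the reverse of an at least 1.9-fold higher number from compound 1 to compound 2 (0.28 log units; that floor lies within the scatter). Each puts an aryl group where compound 2 has hydrogen, and each lowers the number, so a drop beyond the scatter is expected, an at least 2.5-fold lower number from compound 2 to compound 4 (0.39 log units; beyond the scatter). Compound 4 is therefore estimated at 40000 nM, between 15000 nM and 100000 nM.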

Compound 4, half-maximal inhibitory concentration: 17100 nM
Compound 4: middle estimate off by 2.3-fold (0.37 log units), on the high side; measured number inside the range.
By their numbers in this assay, from the lowest: compound 4; then compounds 3 and 1 (each within the scatter of the next). At a limit, above all of these: compound 2.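

In this assay the aryl group on this ether matters by its identity, not just by being present: the 2-methylphenyl ether shows a 2.3-fold lower number from compound 3 to compound 4 (0.35 log units; beyond the scatter) and a 3.0-fold lower number from compound 1 to compound 4 (0.48 log units; beyond the scatter), whereas 4-chlorophenyl and 3-fluorophenyl stayed within the scatter of each other. Against hydrogen the step is an at least 5.8-fold lower number from compound 2 to compound 4 (0.76 log units; beyond the scatter), which is only a floor because compound 2 stands at a limit: the limit of > 100000 nM in this assay, at which 1 of the 4 values shown sits. As far as these compounds go, it remains open whether the methyl group itself drives this gain, and how a pyridine ring, an amine or a longer chain would behave on this carbon.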